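The compounds below may be only part of what the source reports. "The series", "measured", "known", "first", "only" and "open" are said of these compounds alone.

In a functional assay on the whole organism (strain albino) for inhibition, with Rattus norvegicus as the target, read by paw edema, with stated times of 30 min and 4 h, at a dose of 0.28 mmol/kg by the oral route (on this read-out higher numbers stand for more inhibition at the one dose given (going by the name of the read-out) and lower numbers for less inhibition), compound 2, `CCn1c(SCC(=O)Nc2ccc(/C(C)=N/O)cc2)nnc1-c1ccccc1`, gives 77%. Compound 1, `C/C(=N\O)c1ccc(NC(=O)CSc2nnc(-c3ccccc3)n2-c2ccccc2)cc1`, gives 67% in this assay; it differs from compound 2 by phenyl in place of ethyl on an aromatic nitrogen, and on this read-out the change gives a number 10 percentage points lower from compound 2 to compound 1 (within the scatter). Compound 3, `CCn1c(SCC(=O)Nc2ccc(C(C)=O)cc2)nnc1-c1ccccc1`, gives 69% in this assay; its core differs from that of compound 2 by a group of 3 heavy atoms (2 carbon, 1 oxygen; no ring) in place of a group of 4 heavy atoms (2 carbon, 1 nitrogen, 1 oxygen; no ring), on an aromatic carbon, a change that gives a number 8 percentage points lower from compound 2 to compound 3 (within the scatter). Compound 3 thus stands second highest of the three numbers, with compound 1 nearest and compound 2 furthest, all three within the scatter of each other.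

Compound 4, `CC(=O)c1ccc(NC(=O)CSc2nnc(-c3ccccc3)n2-c2ccccc2)cc1`, has not yet been measured in this assay. It differs from compound 3 by phenyl in place of ethyl on an aromatic nitrogen, the same change that is made from compound 2 to compound 1, at the same place, so that among these compounds it occurs twice in all. Resting on the earlier step of a number 10 percentage points lower from compound 2 to compound 1 (within the scatter), which lay within the scatter, the step of a number 9 percentage points lower from compound 3 to compound 4 (within the scatter) is expected. Compound 4 is therefore estimated to give 60%, with a likely range from 48% to 72%.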

Compound 4, a percentage reported as inhibition, in the whole organism at one dose (the size of the read-out at that dose, not a potency): 67%
Compound 4: the middle estimate sits 7 percentage points below what was measured; low and high end bracket the measured number.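

In this assay, phenyl in place of ethyl on an aromatic nitrogen gives a number 2 percentage points lower from compound 3 to compound 4 (within the scatter), and this step agrees with the one seen on the other core: the same change on two cores in this assay, a number 10 percentage points lower (within the scatter) from compound 2 to compound 1 and a number 2 percentage points lower (within the scatter) from compound 3 to compound 4, 8 percentage points apart, within the scatter of two such steps. The exchange of the group on the aromatic carbon gives no change at the digits printed from compound 1 to compound 4 (within the scatter), and it too reads alike on both cores: the same change on two cores in this assay, a number 8 percentage points lower (within the scatter) from compound 2 to compound 3 and no change at the digits printed (within the scatter) from compound 1 to compound 4, 8 percentage points apart, within the scatter of two such steps. Both changes therefore carry from one core to the other within the scatter, but every step here also lies within the scatter, so this does not show that either change has a real effect of its own, and two cores cannot show that the agreement would hold on a third.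

The compounds shown leave open how a longer chain such as butyl, or a benzyl group, would read on the aromatic nitrogen. They also leave open whether a carboxylic acid or an amine on the aromatic carbon would give numbers like these.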